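Dimethylamino for phenoxy: notes toward compound 3

A few compounds are considered here, and "the series" means these few. Any claim that something is new, unique, unknown or untested is made for them only; others in the source may bear on it.

Two compounds of the series carry numbers in a functional assay on NCI-H226 cells (Homo sapiens) for inhibition, read by sulforhodamine B assay, with a stated time of 48 h; a higher number here means a weaker inhibitor of growth, a lower number a stronger inhibitor of growth. Compound 1 `COc1cc(C)cc(-c2c(-c3ccnc(-c4ccc(C(C)=O)cc4)c3)cnn2CC#N)c1` gives 5470 nM in this assay. Compound 2 `Cc1cc(O)cc(-c2nn(CC#N)cc2-c2ccnc(-c3ccc(Oc4ccccc4)cc3)c2)c1` gives 3220 nM in this assay, and the two numbers sit within the usual scatter of each other, so neither compound stands apart. Compound 3 `Cc1cc(O)cc(-c2nn(CC#N)cc2-c2ccnc(-c3ccc(N(C)C)cc3)c2)c1` has not been measured. Relative to compound 2 it carries dimethylamino in place of phenoxy on an aromatic carbon. Among the compounds with values here, no measured pair shows this change, so no step can be read from the data. The expected step is small, a 1.1-fold higher number from compound 2 to compound 3 (0.04 log units; within the scatter), not beyond the scatter and in no firm direction. Compound 3 is accordingly estimated at 3500 nM, within 1200 nM to 10000 nM.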

Compound 3, concentration for 50% growth inhibition: 4180 nM
Beside the measured number, compound 3's estimate is 1.2-fold (0.08 log units) below it, and the stated range covers the measured number.
By their numbers in this assay, from the lowest: compounds 2, 3 and 1 (each within the scatter of the next).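

Within the data shown here, this is the first measured step at this position: in this assay the step of a 1.3-fold higher number from compound 2 to compound 3 (0.11 log units; within the scatter) is within the scatter, so compound 2 and compound 3 cannot be told apart. At this place, para to a large group, phenoxy with its 7 heavy atoms and its ring and dimethylamino with 3 heavy atoms and no ring thus give numbers that do not separate. No supporting evidence bears on this result.

Still open, as far as these compounds go, is whether a carboxylic acid or a primary amine at this place would separate from compound 2.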